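Methoxy for Trifluoromethyl on a Secondary-Amine Core

The compounds below may be only part of what the source reports. "The series", "measured", "known", "first", "only" and "open" are said of these compounds alone.

compound 1 `O=C(Nc1ccc(C(F)(F)F)cc1)C1c2ccccc2CCN1C(=O)c1ccc(Cl)cc1`: 4200 nM
compound 2 `COc1ccc(NC(=O)C2c3ccccc3CCN2C(=O)c2ccc(Cl)cc2)cc1`: 3630 nM
compound 3 `O=C(Nc1cccc(C(F)(F)F)c1)C1NCCc2ccccc21`: a limit, > 10000 nM

In a functional assay on NUGC-3 cells (Homo sapiens) for inhibition, read by sulforhodamine B assay, with a stated time of 48 h (on this read-out lower numbers stand for stronger inhibition of growth and higher numbers for weaker inhibition of growth), compound 1 gives 4200 nM and compound 2 gives 3630 nM. The change between them, (methoxy in place of trifluoromethyl on an aromatic carbon), made a 1.2-fold lower number from compound 1 to compound 2 (0.06 log units; within the scatter). For compound 3 this assay reports only a limit, > 10000 nM, namely (the limit of > 10000 nM in this assay, at which 1 of the 3 values shown sits). The difference between the core of compound 3 and the core of compound 1 is not broken down here. Compound 4 `COc1cccc(NC(=O)C2NCCc3ccccc32)c1` is not yet measured; it differs from compound 3 by methoxy in place of trifluoromethyl on an aromatic carbon. This is the same kind of change as that from compound 1 to compound 2, but the surroundings differ: there the group sits para to a large group, here meta to a large group. Because the measured step of a 1.2-fold lower number from compound 1 to compound 2 (0.06 log units; within the scatter) lay within the scatter, the expected step for compound 4 is a step that the limit leaves unreadable from compound 3 to compound 4. Compound 4 is therefore estimated at 12000 nM, most likely reported again only as a limit.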

Compound 4, concentration for 50% growth inhibition: > 10000 nM
Compound 4: a limit, no number; the forecaster's own chance of this, stated with the estimate: 75%; the middle value lies beyond the limit too.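

In this assay, compound 3 and compound 4 are both reported only as limits, and no step between them can be read: the limit of > 10000 nM in this assay, at which 2 of the 4 values shown sit.

The compounds shown leave open whether methoxy in place of trifluoromethyl changes growth inhibition at all on the core of compound 3.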